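The compounds below may be only part of what the source reports. "The series", "measured", "known", "first", "only" and "open" are said of these compounds alone.

The compounds measured in a physicochemical assay for lipophilicity, using the shake flask method, in phosphate buffer, measured as octanol-water partition, at pH 7.4 (on this read-out lower numbers stand for lower lipophilicity and higher numbers for higher lipophilicity), so far:

Compound 1 `COc1cc(-c2cc(C(=O)O)c3ccccc3n2)ccc1OCC(=O)Nc1ccccc1` gives 0.7.
Compound 2 `COc1cc(-c2cc(C(=O)O)c3ccccc3n2)ccc1OCC(=O)Nc1cccc(Cl)c1` gives 2.3.
Compound 3 `CCCCCCNC(=O)COc1ccc(-c2cc(C(=O)O)c3ccccc3n2)cc1OC` gives 1.

Compound 3 stands second highest of the three. Its nearest neighbour is compound 1, since the step of a number 0.30 log units higher from compound 1 to compound 3 (within the scatter) lies within the scatter, while the step of a number 1.30 log units lower from compound 2 to compound 3 (beyond the scatter) is large. Compound 4 `COc1cc(-c2cc(C(=O)O)c3ccccc3n2)ccc1OCC(=O)NC1CCCCC1` differs from compound 3 only by cyclohexyl in place of hexyl on an amide-type nitrogen. Going by the values given here, no measured step exchanges a chain for a ring on that nitrogen; the closest guide is that compound 1 and compound 3 differ by a number 0.30 log units higher from compound 1 to compound 3 (within the scatter), a change no bigger than the scatter. Compound 4 is therefore expected to move by a number 0.30 log units lower from compound 3 to compound 4 (within the scatter) in this assay, at most a small shift downward. The estimate for compound 4 is 0.7, expected to fall between 0.2 and 1.2.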

Compound 4, distribution coefficient: 0.8
Beside the measured number, compound 4's estimate is 0.10 log units below it; the measured number falls inside the stated range.
By their numbers in this assay, from the lowest: compounds 1, 4 and 3 (each within the scatter of the next); then compound 2.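

In this assay, the cyclohexyl ring of compound 4 reads the same as the open hexyl chain (a number 0.20 log units lower from compound 3 to compound 4 (within the scatter)) and the same as phenyl on the amide-type nitrogen (a number 0.10 log units higher from compound 1 to compound 4 (within the scatter)). Compound 1, compound 3 and compound 4 thus cannot be told apart, whereas compound 2, with 3-chlorophenyl at this place, remains separate from the new ring (a number 1.50 log units lower from compound 2 to compound 4 (beyond the scatter)). No measurement shown accounts for these steps. Going by these compounds, it remains open how an amine or a hydroxyl on the cyclohexyl ring, or a chain longer than hexyl, would read here.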